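Methoxymethyl in Place of Hydrogen on the Core of Compound 1

This account rests on a few compounds, and the source may have more. Where it says the series, first, only, none or still open, it means among the compounds named here.

The measured compounds:
compound 1, `CN1C(=S)[C@@H](NC(=O)c2nc(Cc3ccccc3)n(C)n2)COc2ccccc21` — in a toxicity assay on HT-29 cells (Homo sapiens) for cytotoxicity (on this read-out higher numbers stand for lower toxicity in this test and lower numbers for higher toxicity in this test), compound 1 gives > 100000 nM, which is a limit of the assay.
compound 2, `CC(C)Cn1nc(C(=O)N[C@H]2COc3ccccc3N(C)C2=S)nc1Cc1ccccc1` — compound 2 gives > 100000 nM, which is a limit.
compound 3, `CC(C)CCn1nc(C(=O)N[C@H]2COc3ccccc3N(C)C2=S)nc1Cc1ccccc1` — compound 3 gives > 100000 nM, which is a limit.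

Compound 1 therefore stands at a limit and nowhere else: no number is known for it. The steps a step that the two limits leave unreadable from compound 1 to compound 2, a step that the two limits leave unreadable from compound 1 to compound 3 and a step that the two limits leave unreadable from compound 2 to compound 3 cannot be sized because every value sits at the limit of > 100000 nM in this assay, at which 3 of the 3 values shown sit. Compound 4, `COCCn1nc(C(=O)N[C@H]2COc3ccccc3N(C)C2=S)nc1Cc1ccccc1`, differs from compound 1 by methoxymethyl in place of hydrogen on a saturated chain carbon bound to an aromatic nitrogen. Among the compounds with values here, the steps that bear on this change, from compound 1 to compound 2 and from compound 1 to compound 3, carry the same kind of substitution at the same place and both stay unreadable, so no step beyond the scatter can be expected to become visible for compound 4. The author estimates that compound 4 will again sit at the limit, with an expected step of a number no higher from compound 1 to compound 4 (the limit leaves the size open). Compound 4 is thus expected at 100000 nM, within 50000 nM to 300000 nM.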

Compound 4, half-maximal cytotoxic concentration: > 100000 nM
Compound 4 ended at the assay's limit; the forecaster's own chance of this, stated with the estimate: 85%; the middle value sits exactly at the limit.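

Compound 4 joins compound 1, compound 2 and compound 3 at the same limit, so no new step among these compounds can be read: the limit of > 100000 nM in this assay, at which 4 of the 4 values shown sit.

The compounds shown leave open whether any of these chains would give a number in this assay at all, and how large a step between them would be.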